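The source may hold more compounds than are shown below. What is called first, only, known or untested is meant among the compounds shown, and "the series" means these compounds.

Measured so far:
compound 1 `CCCCn1ccnc1-c1cc(OC)c(OC)c(OC)c1` — 70400 nM
compound 2 `COc1cc(-c2nccn2-c2ccc3sccc3c2)cc(OC)c1OC` — 16800 nM

In a functional assay on MDA-MB-231 cells (Homo sapiens) for antiproliferative activity, read by MTT assay, with a stated time of 72 h (a higher number here means a weaker inhibitor, a lower number a stronger inhibitor), compound 1 gives the highest of the two numbers; compound 2, the nearest, gives 16800 nM, a gap beyond the usual scatter. Compound 3 `COc1ccc(-n2ccnc2-c2cc(OC)c(OC)c(OC)c2)cc1` is not yet measured. It differs from compound 1 by 4-methoxyphenyl in place of butyl on an aromatic nitrogen. Among the compounds with values here, no step between measured compounds guides this change, so the expected size rests on compound 1 alone: a modest move toward a lower number, a 3.2-fold lower number from compound 1 to compound 3 (0.51 log units; beyond the scatter), is expected rather than none. Compound 3 is therefore estimated at 22000 nM, within 7000 nM to 60000 nM.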

Compound 3, half-maximal inhibitory concentration: 2700 nM
Beside the measured number, compound 3's estimate is 8.1-fold (0.91 log units) above it, and the stated range ends above it.
By their numbers in this assay, from the lowest: compound 3; then compound 2; then compound 1.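

In this assay, the substituent on the aromatic nitrogen of the shared core proves to be a strong determinant of the read-out: 4-methoxyphenyl in place of butyl gives a 26-fold lower number from compound 1 to compound 3 (1.42 log units; beyond the scatter), a large step well beyond the scatter. Within the data shown here, this is the first direct reading of any change at this position. Nothing available here explains the size of the step.

The compounds shown leave open whether plain phenyl would give the same step or whether the methoxy group is needed. As far as these compounds go, how an amine or a carboxylic acid on that ring would read also remains open.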